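Swapping 2,3-difluorophenyl for 2,4-difluorophenyl on a carbonyl carbon

The source may report more compounds than this note shows. Statements on the series, on what has been measured and on what is new or still open speak of the compounds shown alone.

Among the compounds with values here, in an ADME assay on MT4 cells (Homo sapiens) for cytotoxicity, read by MTT assay (on this read-out higher numbers stand for lower toxicity in this test and lower numbers for higher toxicity in this test), compound 2 (`O=C1c2ccccc2C(=O)N1CCOC(=S)N(C(=O)c1cccc(F)c1F)c1ccc(Cl)cc1`) gives 58000 nM as the only actual number so far. Compound 1 (`O=C1c2ccccc2C(=O)N1CCOC(=S)N(C(=O)c1ccc([N+](=O)[O-])cc1)c1ccc(Cl)cc1`) gives > 100000 nM in the same test, and this is a limit of the assay rather than a number. Compound 3 (`O=C1c2ccccc2C(=O)N1CCOC(=S)N(C(=O)c1ccc(F)cc1F)c1ccc(Cl)cc1`) carries 2,4-difluorophenyl in place of 2,3-difluorophenyl on a carbonyl carbon. Within the data shown here, only one measured step bears on this, a different swap on that same carbonyl carbon (an at least 1.7-fold lower number from compound 1 to compound 2 (0.23 log units; that floor lies within the scatter)), and it rests on a limit (the limit of > 100000 nM in this assay, at which 1 of the 2 values shown sits). Its floor stays within the scatter, so no step beyond the scatter is expected in this assay from this smaller rearrangement of the same two fluorines. The expected step is therefore slight (a 1.1-fold lower number from compound 2 to compound 3 (0.02 log units; within the scatter)). Compound 3 is estimated at 55000 nM (expected range 25000 nM to 100000 nM).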

Compound 3, half-maximal cytotoxic concentration: 52000 nM
The estimate for compound 3 lay 1.1-fold (0.02 log units) above the measured number; measured number inside the range.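

In this assay, the 2,3-difluorophenyl and 2,4-difluorophenyl groups on this carbonyl carbon cannot be told apart, with a 1.1-fold lower number from compound 2 to compound 3 (0.05 log units; within the scatter). Replacing 4-nitrophenyl with 2,4-difluorophenyl gives an at least 1.9-fold lower number from compound 1 to compound 3 (0.28 log units; that floor lies within the scatter), so a second fluorine arrangement also shows no step beyond the scatter from compound 1. For compound 1, the entry > 100000 nM is a limit of the assay and not a number, so this step is only a floor: the limit of > 100000 nM in this assay, at which 1 of the 3 values shown sits.

Going by these compounds, it remains open whether the read-out at this carbonyl carbon would stay as flat with a different kind of group, such as an amine or a carboxylic acid on the phenyl ring, or a simple methyl in its place. Also open, on these data alone, is whether changes elsewhere on the shared core would move the read-out.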